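The source may report more compounds than this note shows. Statements on the series, on what has been measured and on what is new or still open speak of the compounds shown alone.

Measured so far in a functional assay on HCT-116 cells (Homo sapiens) for antiproliferative activity, read by MTT assay, with a stated time of 48 h; a lower number here means a stronger inhibitor, a higher number a weaker inhibitor:
- compound 1, `Cc1ccc2nc(Nc3ccnc(Nc4ccc(S(C)(=O)=O)cc4)n3)sc2c1`: 1750 nM
- compound 2, `NS(=O)(=O)c1ccc(Nc2nccc(Nc3nc4ccc(F)cc4s3)n2)cc1`: 700 nM
- compound 3, `Cc1cnc(Nc2ccc([N+](=O)[O-])cc2)nc1Nc1nc2ccccc2s1`: 6330 nM

Compound 1 stands second highest of the three numbers. Its nearest neighbour is compound 2, whose number lies lower by more than the scatter; its furthest is compound 3, whose number lies higher, again beyond the scatter. No pair of these compounds differs in one place only, so no single step can be read from them; the three values show only that compound 2 gives the lowest number and compound 3 the highest.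

The next compound, compound 4, `COc1ccc2nc(Nc3ccnc(Nc4ccc(S(C)(=O)=O)cc4)n3)sc2c1`, differs from compound 1 in one place: methoxy in place of methyl on an aromatic carbon. Among the compounds with values here, nothing among the measured compounds isolates this change. The shared core, the linking groups and the methylsulfonyl-bearing ring are untouched, and the change adds one hydrogen-bond acceptor and one heavy atom on the fused ring. Absent any comparable step, the expectation is a step of no clear direction and within the scatter, a 1.2-fold lower number from compound 1 to compound 4 (0.07 log units; within the scatter). Compound 4 is thus estimated at 1500 nM, within 600 nM to 4000 nM.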

Compound 4, half-maximal inhibitory concentration: 2270 nM
Compound 4: middle estimate off by 1.5-fold (0.18 log units), on the low side; low and high end bracket the measured number.
By their numbers in this assay, from the lowest: compound 2; then compounds 1 and 4 (each within the scatter of the next); then compound 3.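

In this assay, within the data shown here, placing methoxy where methyl stood on this aromatic carbon gives a 1.3-fold higher number from compound 1 to compound 4 (0.11 log units; within the scatter), the first single-place step. At this carbon, the added oxygen and its hydrogen-bond acceptor therefore leave the number within the scatter, at least with the rest of the structure of compound 1 held fixed. No supporting measurement bears on this result.

As far as these compounds go, whether an amine or a carboxylic acid on this carbon would move the number beyond the scatter remains open, as does whether the same methoxy for methyl change would give a similar step on a different remainder of the structure. Compound 2 and compound 3 each differ from compound 1 in more than one place, so what separates their numbers cannot be read.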